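A few compounds are considered here, and "the series" means these few. Any claim that something is new, unique, unknown or untested is made for them only; others in the source may bear on it.

Working notes on the series: in a functional assay on HCT-116 cells (Homo sapiens) for inhibition, read by colorimetric assay, with a stated time of 3 days (a higher number here means a weaker inhibitor, a lower number a stronger inhibitor), compound 1 `COc1ccc(OC)c(NC(=O)CCCCCCNC(=O)C(O)(O)C(F)(F)F)c1` reads 3870 nM and compound 3 `O=C(CCCCCCNC(=O)C(O)(O)C(F)(F)F)Nc1ccccc1Br` reads 14500 nM, while compound 2 `COc1ccc(-c2cnc(NC(=O)CCCCCCNC(=O)C(O)(O)C(F)(F)F)s2)cc1` holds the lowest of the three numbers at 930 nM with both gaps beyond the scatter. Compound 4 `O=C(CCCCCCNC(=O)C(O)(O)C(F)(F)F)Nc1ncc(-c2ccc(Br)cc2)s1` departs from compound 2 by bromo in place of methoxy on an aromatic carbon (bromo in place of methoxy on an aromatic carbon, 4-methoxyphenyl to 4-bromophenyl). Among the measured compounds shown here, no measured pair isolates this exchange, so the data give no direct size for it. In this assay no step beyond the scatter is expected, with at most a slight drift towards a lower number. The expected change is a 1.1-fold lower number from compound 2 to compound 4 (0.04 log units; within the scatter) and stays within the scatter. Compound 4 is expected at 850 nM (estimated range 350 nM to 2100 nM).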

Compound 4, half-maximal inhibitory concentration: 2460 nM
The estimate for compound 4 lay 2.9-fold (0.46 log units) below the measured number; measured number outside the range, above it.
By their numbers in this assay, from the lowest: compound 2; then compounds 4 and 1 (each within the scatter of the next); then compound 3.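

At this place, on a six-membered aromatic ring of carbon only and para to a large group, the exchange is not neutral in this assay, where bromo in place of methoxy gives a 2.6-fold higher number from compound 2 to compound 4 (0.42 log units; beyond the scatter) as a modest loss. Among the compounds shown here, this is the only single-place change, so methoxy is favoured over bromo here on this one pair alone. Nothing available accounts for the step.

On these data alone, whether an amine, a carboxylic acid or a chloro group at this place would give a lower number remains open. Also open, as far as these compounds go, is whether the same exchange gives a step of similar size on the cores of compound 1 or compound 3.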